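Hydroxy for Amino on the Indole Ring

The compounds below may be only part of what the source reports. "The series", "measured", "known", "first", "only" and "open" are said of these compounds alone.

Compound 1 `CN1CCCN(CCn2ccc3ccc(Cl)cc32)CC1` gives 85% in an assay on HEK293 cells for binding affinity to 5-hydroxytryptamine receptor 7 (Homo sapiens), read by radioligand binding, tested at 1 uM; a lower number here means less inhibition, a higher number more inhibition at the concentration tested (going by the name of the read-out).
Compound 2 `CN1CCCN(CCn2ccc3ccc(N)cc32)CC1` gives 0% in this assay.

Compound 2 stands lowest of the two measured numbers in this assay; its nearest neighbour is compound 1, a number far higher. Compound 3 `CN1CCCN(CCn2ccc3ccc(O)cc32)CC1` differs from compound 2 by hydroxy in place of amino on an aromatic carbon. Going by the values given here, only one measured step bears on this change: a number 85 percentage points lower from compound 1 to compound 2 (beyond the scatter). That step shows one group at this carbon giving strong inhibition and another giving none, which leaves the hydroxy compound open. Compound 3 is expected to give 25%, within 0% to 65%, an estimated a number 25 percentage points higher from compound 2 to compound 3 (beyond the scatter).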

Compound 3, a percentage reported as inhibition, at one concentration (the size of the read-out at that concentration, not a potency): 28%
Estimate against measurement, compound 3: 3 percentage points below, within the range that was stated.
By their numbers in this assay, from the lowest: compound 2; then compound 3; then compound 1.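

In this assay, hydroxy at this aromatic carbon stands apart from amino, with a number 28 percentage points higher from compound 2 to compound 3 (beyond the scatter), and also from chloro, with a number 57 percentage points lower from compound 1 to compound 3 (beyond the scatter). The three groups thus give three separate levels of inhibition, and hydroxy brings back only part of what separates amino from chloro. No evidence is available that would account for this order. On these data alone, whether bromo, fluoro or methyl at this carbon would match chloro remains open, as does whether methoxy would differ from hydroxy. The readings also come from one concentration, so they leave potency open.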